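The compounds below may be only part of what the source reports. "The series", "measured", "known", "first", "only" and "open" are said of these compounds alone.

Measured in a functional assay on HEK293 cells (Homo sapiens) for cytotoxicity; a higher number here means that more compound is tolerated, a lower number that less compound is tolerated:

Compound 1 (`COc1ccc([C@H]2CC(=O)N(c3cccc(S(C)(=O)=O)c3)C2)cc1OC1CCCC1`): > 10000 nM (a limit)
Compound 2 (`COc1ccc([C@H]2CC(=O)N(c3cccc(NS(=O)(=O)c4cccc(Cl)c4)c3)C2)cc1OC1CCCC1`): > 10000 nM (a limit)

Neither compound gives a number in this assay. Compound 2 stands at > 10000 nM (a limit of the assay, not a measured value). Within the data shown here, the only measured step is a step that the two limits leave unreadable from compound 1 to compound 2, with ((3-chlorophenyl)sulfonyl)amino in place of methylsulfonyl on an aromatic carbon. All that can be taken from it is the limit of > 10000 nM in this assay, at which 2 of the 2 values shown sit (no size, and no direction).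

Compound 3 (`COc1ccc([C@H]2CC(=O)N(c3cccc(NS(=O)(=O)c4ccccc4C)c3)C2)cc1OC1CCCC1`) keeps the core of compound 2 and carries 2-methylphenyl in place of 3-chlorophenyl on a sulfonyl sulfur. Among the measured compounds shown here, no measured step covers this exchange, so the account has no size to carry over. The much larger exchange between compound 1 and compound 2 left the read-out at the limit, and a smaller one is expected to do the same. The expected result is a step that the limit leaves unreadable from compound 2 to compound 3 (nothing beyond the scatter, in either direction). Compound 3 is estimated at 12000 nM (expected range 6000 nM to 30000 nM) and will most likely be reported as a limit again.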

Compound 3, half-maximal cytotoxic concentration: > 10000 nM
Compound 3 was reported as a limit (the forecaster's own chance of this, stated with the estimate: 85%); the middle value lies beyond the limit too.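

In this assay compound 3 gives > 10000 nM, which is a limit. The steps linking compound 1, compound 2 and compound 3 cannot be read, and all that remains is this: the limit of > 10000 nM in this assay, at which 3 of the 3 values shown sit. The compounds shown leave open at what concentration any of them becomes cytotoxic, and whether either exchange changes that concentration at all.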